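Swapping an oxopiperazine for a piperidine in a ghrelin receptor antagonist

This account rests on a few compounds, and the source may have more. Where it says the series, first, only, none or still open, it means among the compounds named here.

Compound 1 `CN1CCN(CC(=O)NC2(c3ccc(Cl)cc3)C(=O)Nc3cc(Cl)ccc32)CC1` and compound 2 `CCN1CCN(CC(=O)NC2(c3ccc(Cl)c(Cl)c3)C(=O)Nc3cc(Cl)cc(Cl)c32)CC1=O` share a core and were both tested in an in vitro functional assay on CHO-CREluc cells for antagonist activity at growth hormone secretagogue receptor type 1 (Homo sapiens), read by a luciferase reporter, with a stated time of 4 h; on this read-out lower numbers stand for stronger inhibition and higher numbers for weaker inhibition. Compound 1 gives 140 nM, whereas compound 2 gives 2780 nM, which is the highest number of the two and therefore the weaker inhibitor, with a gap to compound 1 that lies well beyond the scatter of repeated measurements. Compound 3 `CCN1CCC(CC(=O)NC2(c3ccc(Cl)c(Cl)c3)C(=O)Nc3cc(Cl)cc(Cl)c32)CC1` has not been measured yet. It differs from compound 2 in one place: 1-ethylpiperidin-4-yl in place of 4-ethyl-3-oxopiperazin-1-yl on a saturated chain carbon bound to a carbonyl carbon. The group that leaves carries a six-membered ring with 2 hetero atoms and 1 double bond outside aromatic rings, while the group that enters is a six-membered ring with 1 hetero atom and no such double bond. For the measured compounds named here, no measured pair shows this exact change, so the direction is uncertain, but compound 3 is expected to move toward stronger inhibition, a step of a 4.6-fold lower number from compound 2 to compound 3 (0.67 log units; beyond the scatter). Compound 3 is estimated at 600 nM, within a range from 150 nM to 2500 nM.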

Compound 3, half-maximal inhibitory concentration: 1 nM
Beside the measured number, compound 3's estimate is 600-fold (2.78 log units) above it, outside the stated range (below it).
By their numbers in this assay, from the lowest: compound 3; then compound 1; then compound 2.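

In this assay, putting 1-ethylpiperidin-4-yl in place of 4-ethyl-3-oxopiperazin-1-yl on a saturated chain carbon bound to a carbonyl carbon gives a 2800-fold lower number from compound 2 to compound 3 (3.44 log units; beyond the scatter), so the ring at this position has a very large effect on the read-out. Compound 1 and compound 2 differ in more than one place and could not show this, whereas this single change isolates the position. Nothing available here explains why the step is so large.

The change removes a ring nitrogen and the ring carbonyl together, so the step alone cannot show which of the two matters, or whether both do. A 4-ethylpiperazin-1-yl group, which keeps both ring nitrogens but lacks the carbonyl, would help to separate them.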